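The source may hold more compounds than are shown below. What is called first, only, known or untested is meant among the compounds shown, and "the series" means these compounds.

Working notes on the series. Going by the values given here, compound 1 `Cc1c(Br)sc(N)c1C(=O)c1ccc(Cl)cc1` and compound 2 `CC(C)(C)Cc1c(-c2ccc(F)cc2)sc(N)c1C(=O)c1ccc(Cl)cc1` share one core and differ from each other in two places on that core, so no single-change step between them can be drawn; only their two values can be set side by side. In an assay on CHO cells for displacement of a labelled ligand from adenosine receptor A1 (Homo sapiens), read by scintillation counting, tested at 10 uM (a lower number here means less inhibition, a higher number more inhibition at the concentration tested (going by the name of the read-out)), compound 1 gives 1%. In this assay compound 2 gives 1%, level with compound 1 at the digits shown and within the usual scatter of the measurement, so the two values show no difference between them. Compound 3 `COc1ccc(-c2sc(N)c(C(=O)c3ccc(Cl)cc3)c2CC(C)(C)C)cc1` has not yet been measured. It differs from compound 2 in one place: methoxy in place of fluoro on an aromatic carbon. Among the compounds with values here, both measured compounds sit at the floor of the inhibition read-out in this assay, and no measured step is available to show how a change of this kind moves the read-out. The expected step in this assay is therefore a number 1 percentage points higher from compound 2 to compound 3 (within the scatter), which is none beyond the scatter. Compound 3 is expected to give 2% in this assay, with a range from 0% to 14%.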

Compound 3, a percentage reported as inhibition, at one concentration (the size of the read-out at that concentration, not a potency): 1%
The estimate for compound 3 lay 1 percentage points above the measured number, and the stated range covers the measured number.
By their numbers in this assay, from the lowest: compounds 1, 2 and 3 (each within the scatter of the next).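

Going by these compounds alone, the first single-change step reads, in this assay, no change at the digits printed from compound 2 to compound 3 (within the scatter), for 4-fluorophenyl to 4-methoxyphenyl. This position therefore accepts methoxy, with 2 heavy atoms and 1 hydrogen-bond acceptor, in place of fluoro, with 1 heavy atom and 0 hydrogen-bond acceptors, with no difference in the read-out; both compounds remain at its floor, so the step cannot show how this change would act on a compound with measurable inhibition. No measurement available here bears on the reason for this result.

Going by these compounds, whether an amine or a carboxylic acid at this position would lift the read-out off the floor remains open. Also open, on these data alone, is whether the change from fluoro to methoxy would read the same on a compound with inhibition clearly above the floor.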